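Lengthening the Hydroxyalkoxy Chain on a Shared Core

The source may report more compounds than this note shows. Statements on the series, on what has been measured and on what is new or still open speak of the compounds shown alone.

Compound 1 `CN(C)c1cc2c(NC3CCCCC3)ncnc2cn1` gives 199 nM in a functional assay on CHO cells for antagonist activity at metabotropic glutamate receptor 1 (Rattus norvegicus), with a stated time of 5 min; a lower number here means a stronger inhibitor, a higher number a weaker inhibitor.
Compound 2 `c1ccc2c(NC3CCCCC3)ccnc2c1` gives 6160 nM in this assay.
Compound 3 `OCCOc1cc2c(NC3CCCCC3)ncnc2cn1` gives 177 nM in this assay.

Compound 3 carries the lowest number of the three, yet the step of a 1.1-fold lower number from compound 1 to compound 3 (0.05 log units; within the scatter) lies within the scatter, so compound 1 and compound 3 cannot be ranked. Compound 2, built on a different core, sits far higher, beyond the scatter.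

Compound 4 `OCCCOc1cc2c(NC3CCCCC3)ncnc2cn1` differs from compound 3 by hydroxymethyl in place of hydroxy on a saturated chain carbon, two bonds along the chain from an oxygen on an aromatic ring. Going by the values given here, the only measured step at this position, a 1.1-fold lower number from compound 1 to compound 3 (0.05 log units; within the scatter), swapped the whole group without moving the number; no step tests chain length itself. The step of a 1.1-fold higher number from compound 3 to compound 4 (0.05 log units; within the scatter) is therefore expected to stay within the scatter. Compound 4 is estimated at 200 nM, in a range from 80 nM to 500 nM.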

Compound 4, inhibition constant: 33 nM
Estimate against measurement, compound 4: 6.1-fold (0.78 log units) above; the whole stated range lies above it.
By their numbers in this assay, from the lowest: compound 4; then compounds 3 and 1 (each within the scatter of the next); then compound 2.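

Chain length at this position does matter in this assay: 2-hydroxyethoxy to 3-hydroxypropoxy gives a 5.4-fold lower number from compound 3 to compound 4 (0.73 log units; beyond the scatter) on the shared core, though the earlier swap of dimethylamino for 2-hydroxyethoxy stayed within the scatter. Going by these compounds alone, replacing dimethylamino with 3-hydroxypropoxy gives a 6.0-fold lower number from compound 1 to compound 4 (0.78 log units; beyond the scatter) in the same assay, so this longer group also separates from the one in compound 1. Nothing available explains why the change has this effect. From the compounds shown here alone, whether 4-hydroxybutoxy, a still longer chain, would lower the number further remains open, as does whether an amine could replace the terminal hydroxy.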